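Swapping an Amide for Fluorine on the Indole-like Ring

The source may report more compounds than this note shows. Statements on the series, on what has been measured and on what is new or still open speak of the compounds shown alone.

Measured compounds:
- compound 1, `CCC1C(=O)N(C)c2cnc(-n3ccc4cc(C(=O)NC)ccc43)nc2N1c1ccn(C)n1`: 13200 nM
- compound 2, `CC[C@@H]1C(=O)N(C)c2cnc(Nc3ccc(S(N)(=O)=O)cc3)nc2N1C1CCCC1`: 1300 nM

In a functional assay on Huh-7 cells (Homo sapiens) for antiproliferative activity, read by CCK-8 assay, with a stated time of 72 h (on this read-out lower numbers stand for stronger inhibition of growth and higher numbers for weaker inhibition of growth), compound 1 gives 13200 nM, the higher of the two numbers measured. Compound 2 gives 1300 nM, a lower number that lies beyond the scatter, so compound 2 inhibits growth more strongly. Compound 3, `CCC1C(=O)N(C)c2cnc(-n3ccc4cc(F)ccc43)nc2N1c1ccn(C)n1`, is not yet measured. It differs from compound 1 in one place: fluoro in place of methylcarbamoyl on an aromatic carbon. Going by the values given here, no measured pair shows this change, so its effect is unknown; the expected step in this assay from compound 1 to compound 3 is a 1.2-fold higher number from compound 1 to compound 3 (0.08 log units; within the scatter), roughly within the scatter. Compound 3 is therefore expected near 16000 nM, between 5000 nM and 50000 nM.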

Compound 3, concentration for 50% growth inhibition: "not active" (no number reported)
No number was reported for compound 3, and the estimate cannot be compared.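

Going by these compounds alone, compound 3 is reported as "not active" without a number in this assay, so no step from compound 1 to compound 3 can be read. No further data bear on this result. From the compounds shown here alone, the size of the effect of fluoro in place of methylcarbamoyl on growth inhibition stays open.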